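This account rests on a few compounds, and the source may have more. Where it says the series, first, only, none or still open, it means among the compounds named here.

Compound 3, `Cc1cnc(Nc2ccc(Cl)cc2)nc1Nc1nc2ccccc2s1`, is one of three close relatives in which only the group on the outer phenyl ring changes. In a functional assay on HeLa cells (Homo sapiens) for antiproliferative activity, read by MTT assay, with a stated time of 48 h (a lower number here means a stronger inhibitor, a higher number a weaker inhibitor), compound 3 reaches only a limit, > 50000 nM. Compound 1, `Cc1cnc(Nc2ccc(C(C)C)cc2)nc1Nc1nc2ccccc2s1`, likewise gives only a limit in this assay, > 50000 nM. Compound 2, `Cc1cnc(Nc2ccc([N+](=O)[O-])cc2)nc1Nc1nc2ccccc2s1`, gives a measured number in this assay, 34300 nM. the limit of > 50000 nM in this assay, at which 2 of the 3 values shown sit, is the reason two of the three measured steps can be read only as floors: an at least 1.4-fold lower number from compound 1 to compound 2 (0.16 log units; that floor lies within the scatter), an at least 1.4-fold higher number from compound 2 to compound 3 (0.16 log units; that floor lies within the scatter), and a step that the two limits leave unreadable from compound 1 to compound 3. Compound 4, `COc1cccc(Nc2ncc(C)c(Nc3nc4ccccc4s3)n2)c1`, carries a different outer ring: 3-methoxyphenyl in place of 4-chlorophenyl on a nitrogen on an aromatic ring. Among the measured compounds shown here, none of the measured steps brings in a methoxy group, so none of them bears directly on this change; what they do show is that all three relatives sit at or near the top of the measurable range, whatever the group on the outer ring. Compound 4 is therefore expected to stay weak, with a step that the limit leaves unreadable from compound 3 to compound 4 as the estimated step, most likely ending again at a limit rather than a number. The estimate for compound 4 is 60000 nM, with a range from 25000 nM to 150000 nM.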

Compound 4, half-maximal inhibitory concentration: > 50000 nM
Compound 4 gave a limit, no number; the forecaster's own chance of this, stated with the estimate: 65%; the middle value lies beyond the limit too.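

The 3-methoxyphenyl group, which differs from the other outer rings in both its substituent and that substituent's printed position, adds a further compound without a number in this assay: the limit of > 50000 nM in this assay, at which 3 of the 4 values shown sit. Among the compounds shown here, the one step that can be read is an at least 1.4-fold higher number from compound 2 to compound 4 (0.16 log units; that floor lies within the scatter), so it gives a floor rather than a size and does not separate compound 4 from compound 2 beyond the usual scatter. The steps to compound 4 from compound 1 and from compound 3 cannot be read.

The compounds shown leave open whether an amine or a carboxylic acid on the outer ring would give a clearly measurable number in this assay. They also leave open how far apart compound 1, compound 3 and compound 4 lie, as all three stop at the same limit.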